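The source may report more compounds than this note shows. Statements on the series, on what has been measured and on what is new or still open speak of the compounds shown alone.

Working notes on the series. Compound 1 `Nc1ncn(CCC2(N)OC(=O)C(OCc3ccccc3)=C2OCc2ccccc2)c(=O)n1` and compound 2 `NC1(CCn2c(=O)[nH]c(=O)[nH]c2=O)OC(=O)C(OCc2ccccc2)=C1OCc1ccccc1` share one core; compound 3 `O=C1O[C@H]([C@@H](O)Cn2c(=O)[nH]c(=O)[nH]c2=O)C(OCc2ccccc2)=C1OCc1ccccc1` and compound 4 `Nc1ncn(C[C@H](O)[C@H]2OC(=O)C(OCc3ccccc3)=C2OCc2ccccc2)c(=O)n1` share another, and the difference between the two cores is not broken down here. One change recurs twice: from compound 2 to compound 1 it is a group of 8 heavy atoms (3 carbon, 4 nitrogen, 1 oxygen; one six-membered aromatic ring with 3 hetero atoms) in place of a group of 9 heavy atoms (3 carbon, 3 nitrogen, 3 oxygen; one six-membered aromatic ring with 3 hetero atoms), on a saturated chain carbon, two bonds along the chain from a saturated ring carbon, and from compound 3 to compound 4 it is a group of 8 heavy atoms (3 carbon, 4 nitrogen, 1 oxygen; one six-membered aromatic ring with 3 hetero atoms) in place of a group of 9 heavy atoms (3 carbon, 3 nitrogen, 3 oxygen; one six-membered aromatic ring with 3 hetero atoms), on a saturated chain carbon, two bonds along the chain from an oxygen on a saturated carbon and a saturated ring carbon. The surroundings of the place are not identical: in compound 2 the saturated chain carbon is two bonds along the chain from a saturated ring carbon, whereas in compound 3 it is two bonds along the chain from an oxygen on a saturated carbon and a saturated ring carbon, so the two are the same kind of change, not the same change.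

In a functional assay on HepG2 cells (Homo sapiens) for inhibition, read by MTT assay, with a stated time of 72 h (on this read-out lower numbers stand for stronger inhibition and higher numbers for weaker inhibition), compound 2 gives > 100000 nM, which is a limit of the assay and not a number. Compound 1 gives > 100000 nM in this assay, also a limit. Compound 3 gives > 100000 nM in this assay, again a limit. The measured step that the two limits leave unreadable from compound 2 to compound 1 is therefore unreadable because of the limit of > 100000 nM in this assay, at which 3 of the 3 values shown sit.

For compound 4 the step that the limit leaves unreadable from compound 3 to compound 4 is expected to stay within the scatter, resting on compound 3 at > 100000 nM. Compound 4 is accordingly estimated at 150000 nM in this assay, within an expected range from 60000 nM to 400000 nM, most probably reported as a limit once more.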

Compound 4, half-maximal inhibitory concentration: > 100000 nM
Compound 4 ended at the assay's limit; the forecaster's own chance of this, stated with the estimate: 85%; the middle value is on the limit's open side.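

The change from compound 3 to compound 4 gives no readable step, because both compounds stand at a limit of the assay and not at a number: the limit of > 100000 nM in this assay, at which 4 of the 4 values shown sit.

The compounds shown leave open whether exchanging these two groups alters inhibition at all in this assay, on either core, and how far compound 1, compound 2, compound 3 and compound 4 each lie past the limit.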